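A few compounds are considered here, and "the series" means these few. Any claim that something is new, unique, unknown or untested is made for them only; others in the source may bear on it.

In a functional assay on Malme-3M cells (Homo sapiens) for antiproliferative activity, read by sulforhodamine B assay, with a stated time of 48 h (a higher number here means a weaker inhibitor, a lower number a stronger inhibitor), compound 1 `O=C(NCCCNc1cc(-c2cn(-c3ccccc3)nc2-c2cccc(O)c2)ccn1)Nc1ccc(F)cc1` gives 830 nM and compound 2 `O=C(NCCCNc1cc(-c2cn(-c3ccccc3)nc2-c2cccc(O)c2)ccn1)Nc1cccc(C(F)(F)F)c1` gives 1540 nM. Among the measured compounds shown here, these are the only two numbers available, and they cannot be ranked: the step between them, a 1.9-fold higher number from compound 1 to compound 2 (0.27 log units; within the scatter), places 3-(trifluoromethyl)phenyl where 4-fluorophenyl stood. Compound 3 `COc1cccc(-c2nn(-c3ccccc3)cc2-c2ccnc(NCCCNC(=O)Nc3ccc(F)cc3)c2)c1` keeps the 4-fluorophenyl of compound 1 and differs at another place, with hydroxy going to methoxy on the 3-hydroxyphenyl group: methyl in place of hydrogen on an oxygen on an aromatic ring. For the measured compounds named here, no measured step touches that oxygen, and the one available step shows only that a change elsewhere on the molecule stayed within the scatter. With so little evidence, only a modest shift toward a higher number in this assay is expected, and the expected step, a 1.7-fold higher number from compound 1 to compound 3 (0.23 log units; within the scatter), is not clearly beyond the scatter. For compound 3 the estimated value is 1400 nM, with an expected range from 450 nM to 4500 nM.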

Compound 3, half-maximal inhibitory concentration: 5450 nM
Compound 3: the middle estimate sits 3.9-fold (0.59 log units) below what was measured, outside the stated range (above it).
By their numbers in this assay, from the lowest: compounds 1 and 2 (each within the scatter of the next); then compound 3.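

The oxygen on the aromatic ring is a place where a single small change moves the number beyond the scatter: in this assay, going from hydroxy to methoxy gives a 6.6-fold higher number from compound 1 to compound 3 (0.82 log units; beyond the scatter). The only other step shown, at the aryl group on the amide-type nitrogen, stayed within the scatter, so this methyl on the oxygen, a single added carbon, is the one change here that clearly weakens antiproliferative activity. Nothing measured here accounts for the size of this step.

On these data alone, it remains open whether the free hydroxy is what matters or whether other groups could stand in its place, such as an amine, a fluorine atom or an ethoxy group. As far as these compounds go, it is also open whether methoxy would give a similar step with 3-(trifluoromethyl)phenyl in place of 4-fluorophenyl.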